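This account rests on a few compounds, and the source may have more. Where it says the series, first, only, none or still open, it means among the compounds named here.

Three compounds built on the same core were tested in an ADME assay on MRC5 cells (Homo sapiens) for cytotoxicity, read by fluorescence and resazurin assay, with a stated time of 3 days; on this read-out lower numbers stand for stronger inhibition and higher numbers for weaker inhibition. Compound 1 `Cc1cn(C2CCN(Cc3cc(Oc4ccccc4)ccn3)CC2)c(=O)[nH]c1=O` gives a reading of > 64000 nM in this assay, which is a limit of the assay rather than a number. Compound 2 `Cc1cn(C2CCN(Cc3cccc(Oc4ccccc4)n3)CC2)c(=O)[nH]c1=O` likewise gives > 64000 nM, again a limit. Compound 3 `Cc1cn(C2CCN(Cc3cccc(Oc4cccc(F)c4)c3)CC2)c(=O)[nH]c1=O` returns > 64000 nM, once more a limit. Where compound 3 stands can thus be stated only as a limit, and the same holds for the two other values shown, since (the limit of > 64000 nM in this assay, at which 3 of the 3 values shown sit). Among the measured compounds shown here, no step between measured compounds can be computed; every measured value is a limit.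

Compound 4 `COc1cccc(Oc2cccc(CN3CCC(n4cc(C)c(=O)[nH]c4=O)CC3)c2)c1` has not yet been measured in this assay. It differs from compound 3 in one place: methoxy in place of fluoro on an aromatic carbon. For the measured compounds named here, with every measured value sitting at the limit, there is no measured step to guide the size or direction of what comes next. The expected step in this assay, a step that the limit leaves unreadable from compound 3 to compound 4, is therefore none beyond the scatter. Compound 4 is expected most likely to return a limit as well. Should a number emerge, compound 4 is estimated at 90000 nM in this assay, within a range from 40000 nM to 200000 nM.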

Compound 4, half-maximal inhibitory concentration: 25300 nM
Estimate against measurement, compound 4: 3.6-fold (0.55 log units) above; the whole stated range lies above it.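

In this assay, among the compounds shown here, methoxy in place of fluoro on this aromatic carbon gives an at least 2.5-fold lower number from compound 3 to compound 4 (0.40 log units; beyond the scatter), the first sign that a change at this position can move the read-out. For the compounds shown here, compound 4 gives 25300 nM, the first value here that is a real number rather than a limit, so the compound carrying the 3-methoxyphenoxy group shows a measurable effect on these cells. Only the minimum size of this step can be read, and the true gap may be larger, because compound 3 has no exact value: the limit of > 64000 nM in this assay, at which 3 of the 4 values shown sit.

The compounds shown leave open whether the lower number follows from the methoxy group as a whole or from its oxygen or its carbon alone, and a hydroxy, methyl or ethoxy group at this same place would help to separate these possibilities. As far as these compounds go, it is also open whether a methoxy group would produce a similar step on the closely related compounds 1 and 2, whose readings are limits.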